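The compounds below may be only part of what the source reports. "The series", "measured", "known", "first", "only" and "open" are said of these compounds alone.

In a set of three closely related compounds, compound 1 `Cc1cc(Nc2cc(-c3ccccc3)[nH]n2)n2nc(SCc3ccc(F)cc3)nc2n1`, compound 2 `Cc1cc(Nc2cc(-c3ccccc3)[nH]n2)n2nc(SCc3ccc(Cl)cc3)nc2n1` and compound 3 `Cc1cc(Nc2cc(-c3ccc(Cl)cc3)[nH]n2)n2nc(SCc3ccc(Br)cc3)nc2n1` were each tested in a functional assay on MCF7 cells (Homo sapiens) for inhibition, read by MTT assay, with a stated time of 72 h; a higher number here means a weaker inhibitor, a lower number a stronger inhibitor. Compound 1 gives 4020 nM, compound 2 gives 8260 nM and compound 3 gives 3620 nM in this assay.

Compound 2 and compound 1 differ in one place: fluoro in place of chloro on an aromatic carbon. That change carried a step of a 2.1-fold lower number from compound 2 to compound 1 (0.31 log units; beyond the scatter) in this assay. Compound 3 and compound 2 differ in more than one place, and the difference between the two cores is not broken down here. Compound 3 gives the lowest number of the three, but its gap to compound 1 lies within the scatter, while its gap to compound 2 lies beyond it.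

A fourth compound, compound 4 `Cc1cc(Nc2cc(-c3ccc(F)cc3)[nH]n2)n2nc(SCc3ccc(Br)cc3)nc2n1`, has not yet been measured. It stands to compound 3 as compound 1 stands to compound 2: fluoro in place of chloro on an aromatic carbon. The place reads the same in both cases, yet cut one bond further out the earlier change concerned the (4-chlorobenzyl)sulfanyl group, while here it concerns the 4-chlorophenyl group on the other side of the shared core, so it is the same kind of change on a different ring. On the strength of the step from compound 2 to compound 1, which gave a 2.1-fold lower number from compound 2 to compound 1 (0.31 log units; beyond the scatter), compound 4 is expected to sit somewhat lower than compound 3, though with less confidence because that step was a 2.1-fold lower number from compound 2 to compound 1 (0.31 log units; beyond the scatter) on another ring, and compound 4 is estimated to show a 1.4-fold lower number from compound 3 to compound 4 (0.14 log units; within the scatter) in this assay. Compound 4 is therefore estimated at 2600 nM, within a range from 1200 nM to 6000 nM.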

Compound 4, half-maximal inhibitory concentration: 4570 nM
The estimate for compound 4 lay 1.8-fold (0.24 log units) below the measured number; the range from low to high includes it.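

In this assay, within the data shown here, the swap on the 4-chlorophenyl group, fluoro in place of chloro on an aromatic carbon, gave a 1.3-fold higher number from compound 3 to compound 4 (0.10 log units; within the scatter), so on this core the change left no step that stands clear of the scatter. Set beside the earlier swap on the (4-chlorobenzyl)sulfanyl group, the two steps point in opposite directions, yet they cannot be told apart: the same change on two cores in this assay, a 2.1-fold lower number (0.31 log units; beyond the scatter) from compound 2 to compound 1 and a 1.3-fold higher number (0.10 log units; within the scatter) from compound 3 to compound 4, 2.6-fold (0.41 log units) apart, within the scatter of two such steps. Among these compounds, this shows that the clear step seen on the first core did not reappear on the second, but it does not show that the change behaves differently from one core to the other, and with only one pair on each core and the swap on a different ring in each, neither a transferable effect nor a core-dependent one can be claimed.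

The compounds shown leave open whether the same swap on the 4-chlorophenyl group would give a clearer step with the bromo or fluoro group on the benzyl ring held differently, and how the number would respond to a methoxy group, a nitrile or an amine in place of the halogen on either ring. They also leave open whether a longer chain in place of the benzyl link would change the picture.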